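The source may hold more compounds than are shown below. What is called first, only, known or untested is meant among the compounds shown, and "the series" means these compounds.

Two carbamates on the shared core of compound 2 have been measured. In a functional assay on MCF7 cells (Homo sapiens) for cytotoxicity, read by MTT assay, with a stated time of 72 h (on this read-out lower numbers stand for higher toxicity in this test and higher numbers for lower toxicity in this test), compound 1 `COc1ccc(OC(=O)Nc2ccc([Se]C#N)cc2)cc1` gives 74100 nM; compound 2 `CCCOC(=O)Nc1ccc([Se]C#N)cc1` gives 67500 nM, the lowest of the two numbers, with compound 1 nearest and within the scatter. Compound 3 `CCCCCCOC(=O)Nc1ccc([Se]C#N)cc1` is the next member, not yet measured in this assay. It differs from compound 2 by propyl in place of hydrogen on a saturated chain carbon, three bonds along the chain from an oxygen next to a carbonyl group. Among the compounds with values here, no measured pair shows this change; the expected step of a 1.4-fold lower number from compound 2 to compound 3 (0.13 log units; within the scatter) is of modest size, toward a lower number or none beyond the scatter. Compound 3 is therefore estimated at 50000 nM, within 20000 nM to 120000 nM.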

Compound 3, concentration lethal to 50% of the cells: 63900 nM
Compound 3: middle estimate off by 1.3-fold (0.11 log units), on the low side; measured number inside the range.
By their numbers in this assay, from the lowest: compounds 3, 2 and 1 (each within the scatter of the next).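

Propyl in place of hydrogen on a saturated chain carbon, three bonds along the chain from an oxygen next to a carbonyl group, now has a measured step: in this assay the change gives a 1.1-fold lower number from compound 2 to compound 3 (0.02 log units; within the scatter), so lengthening propyl to hexyl here shifts the number no further than the scatter. Nothing measured on these compounds accounts for this result. Still open, from the compounds shown here alone, is whether a longer chain such as decyl, or a chain ending in an amine or a carboxylic acid, would move the number beyond the scatter.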